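Compound 3 and the Untested Compound 4

The compounds below may be only part of what the source reports. "The series", "measured", "known", "first", "only" and "open" are said of these compounds alone.

Of the compounds shown here, three sharing one core have been measured in a physicochemical assay for lipophilicity, read by HPLC, in phosphate buffer, measured as chromatographic lipophilicity, at pH 7.4; on this read-out lower numbers stand for lower lipophilicity and higher numbers for higher lipophilicity. Compound 1 `Cc1cc(C)cc(NC(=O)COc2cc(C)nc3ccc(OC(F)(F)F)cc23)c1` gives 6.79 in this assay, and compound 2 `CCC(Oc1cc(C)nc2ccc(OC)cc12)C(=O)Nc1cc(C)cc(C)c1` gives 6.28. Compound 3 `COc1ccc2nc(C)cc(OCC(=O)Nc3cc(C)ccc3OC)c2c1` stands lowest of the three in this assay at 5.65; its nearest neighbour is compound 2, whose number lies higher by a gap beyond the scatter, and compound 1 lies further above it, also beyond the scatter. Compound 4 `COc1ccc2nc(C)cc(OCC(=O)NNC(=O)c3ccncc3)c2c1` has not yet been measured in this assay. Among the compounds with values here, it differs from compound 3 in one place: ((pyridin-4-yl)carbonyl)amino in place of 2-methoxy-5-methylphenyl on an amide-type nitrogen No measured pair shows a change of this kind, so the expectation rests on the change itself. The step expected from compound 3 to compound 4 in this assay is a number 1.95 log units lower from compound 3 to compound 4 (beyond the scatter), a fall beyond the scatter. Compound 4 is therefore estimated at 3.7 in this assay, within a range from 2.9 to 4.5.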

Compound 4, distribution coefficient: 1.48
Beside the measured number, compound 4's estimate is 2.22 log units above it; the whole stated range lies above it.
By their numbers in this assay, from the lowest: compound 4; then compound 3; then compound 2; then compound 1.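

In this assay, within the data shown here, the change on this amide-type nitrogen gives a number 4.17 log units lower from compound 3 to compound 4 (beyond the scatter) and is the first single change at this position that can be read, as no earlier pair differed in one place. The entering ((pyridin-4-yl)carbonyl)amino and the leaving 2-methoxy-5-methylphenyl both count 9 heavy atoms, so this step arises with no change in that count. Nothing measured here gives a reason for the step.

The compounds shown do not separate the ring nitrogen from the added carbonyl and amino link. A benzoylamino group or a directly attached pyridin-4-yl group in the same place would part the two.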